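The source may report more compounds than this note shows. Statements on the series, on what has been measured and on what is new or still open speak of the compounds shown alone.

Three compounds sharing one core have entries in a functional assay on the whole organism (strain balb/c) with Mus musculus as the target, with a stated time of 30 min; on this read-out higher numbers stand for an effect only at larger amounts of compound and lower numbers for an effect already at smaller amounts. Compound 1 `CCN(CC)Cc1cc2c(N)nc(-c3ccco3)nc2s1` has the entry "not determined" (no result reported) and so offers no number to compare. Compound 2 `Cc1ccc(-c2nc(N)c3cc(CN4CCc5ccccc5C4)sc3n2)o1` likewise has the entry "not determined" (no result reported) and offers none. Compound 3 `Nc1nc(-c2ccco2)nc2sc(CN3CC=CCC3)cc12` shows < 3 mg/kg as its entry, which is a limit and not a number.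

Compound 4 `Nc1nc(-c2ccco2)nc2sc(CN3CC=CC3)cc12` has not yet been measured. It differs from compound 3 in one place, on a saturated chain carbon bound to an aromatic carbon (a group of 5 heavy atoms (4 carbon, 1 nitrogen; one five-membered non-aromatic ring with 1 hetero atom) in place of a group of 6 heavy atoms (5 carbon, 1 nitrogen; one six-membered non-aromatic ring with 1 hetero atom), on a saturated chain carbon bound to an aromatic carbon). A five-membered non-aromatic ring with 1 hetero atom stands in place of a six-membered one, and 1 double bond outside aromatic rings remains.

Among the compounds with values here, no measured pair shows what this change does, so no step beyond the usual scatter is expected in this assay in either direction. Within the data shown here, this expectation rests on compound 3 and its limit of < 3 mg/kg as the only reading. The expected change is a step that the limit leaves unreadable from compound 3 to compound 4 and remains a rough estimate. The estimate for compound 4 is 2 mg/kg with 0.7 mg/kg to 6 mg/kg as the expected range.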

Compound 4, dose for half-maximal effect: < 0.1 mg/kg
Compound 4 was reported as a limit; the forecaster's own chance of this, stated with the estimate: 40%; at least 20-fold (1.30 log units) between middle value and limit.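

In this assay, within the data shown here, compound 3 and compound 4 both carry limits and not numbers, and no step between the two can be read. The compounds shown leave open whether putting the five-membered non-aromatic ring in place of the six-membered one changes the dose needed, and by how much.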